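The source may hold more compounds than are shown below. What is called first, only, known or untested is meant among the compounds shown, and "the series" means these compounds.

Compound 1 `CCNc1cc(Oc2ccc(NC(=O)Nc3cccc(C(F)(F)F)c3)cc2)ncn1`, compound 2 `CCc1cc(NC(=O)Nc2cccc(C(F)(F)F)c2)cc(Cl)c1Oc1cc(NC)ncn1` and compound 3 `Cc1cc(Oc2ccc(NC(=O)Nc3cccc(C(F)(F)F)c3)cc2)ncn1` have each been tested in an assay on isolated protein for inhibition of serine/threonine-protein kinase TNNI3K (Homo sapiens); a higher number here means a weaker inhibitor, a lower number a stronger inhibitor. Compound 1 gives 25 nM in this assay. For compound 2 the result in this assay is a limit of the assay rather than a number, <= 10 nM, as noted in the limit of <= 10 nM in this assay, at which 1 of the 3 values shown sits. Compound 3 gives 160 nM in this assay, the highest of the two numbers shown, with compound 1 as its nearest neighbour. Within the data shown here, the single measured step between compounds differing in one place is a 6.4-fold higher number from compound 1 to compound 3 (0.81 log units; beyond the scatter), which shows that swapping the ethylamino group for a methyl group on the shared core costs a modest but real amount of potency.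

Compound 4 `CC(=O)Nc1cc(Oc2ccc(NC(=O)Nc3cccc(C(F)(F)F)c3)cc2)ncn1` has not yet been measured. It differs from compound 3 by acetamido in place of methyl on an aromatic carbon. Among the measured compounds shown here, the acetamido group brings back a hydrogen-bond donor and a hydrogen-bond acceptor at the carbon where compound 1 carries ethylamino, and the only measured guide, a 6.4-fold higher number from compound 1 to compound 3 (0.81 log units; beyond the scatter), points toward a lower number. On that basis compound 4 is expected to give about 40 nM in this assay, with a likely range from 12 nM to 160 nM. The expected step is a 4.0-fold lower number from compound 3 to compound 4 (0.60 log units; beyond the scatter).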

Compound 4, half-maximal inhibitory concentration: 20 nM
For compound 4 the middle estimate is 2.0-fold (0.30 log units) above the measured one, and the stated range covers the measured number.
By their numbers in this assay, from the lowest: compounds 4 and 1 (each within the scatter of the next); then compound 3. At a limit, below all of these: compound 2.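

Acetamido on this aromatic carbon, next to the ring nitrogen, regains the potency that methyl gave up in this assay, with an 8.0-fold lower number from compound 3 to compound 4 (0.90 log units; beyond the scatter) on the shared core. Changing the group on that attached nitrogen makes no readable difference, with a 1.3-fold lower number from compound 1 to compound 4 (0.10 log units; within the scatter) even though acetyl replaces ethyl, so among compounds 1, 3 and 4 the two groups joined through nitrogen sit level and compound 3, with methyl, is the weaker one. No measurement shown gives a reason for this gain.

Going by these compounds, it remains open whether the attached nitrogen alone is enough, which a plain amino group at this carbon would test. A methoxy group would ask whether an oxygen there could serve equally well, and a longer chain on the nitrogen would show how much size this position accepts.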